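Phenyl in place of isobutyl: expected permeability of compound 3

A few compounds are considered here, and "the series" means these few. Any claim that something is new, unique, unknown or untested is made for them only; others in the source may bear on it.

Going by the values given here, compound 1 `CC(C)Cc1ccc2c(NCCCNCc3ccco3)ccnc2c1` is the weaker-crossing member of the two compounds measured so far. In an ADME assay for permeability, using PAMPA, with a stated time of 30 min, at pH 7.4 (a higher number here means that the compound crosses the layer faster, a lower number that the compound crosses the layer more slowly), compound 1 gives 23 10^-6 cm/s. Compound 2 `COc1ccc(F)cc1CNCCCNc1ccnc2cc(Oc3ccc(C(C)(C)C)cc3)ccc12` gives 317 10^-6 cm/s in this assay, and compound 1 therefore stands lowest of the two numbers, with the gap to compound 2 beyond the scatter of repeated measurements. Among the compounds with values here, no single-point step between measured compounds has been recorded, so the two values can only be set side by side.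

Compound 3 `c1ccc(-c2ccc3c(NCCCNCc4ccco4)ccnc3c2)cc1` differs from compound 1 by one change: phenyl in place of isobutyl on an aromatic carbon. Within the data shown here, no measured precedent for this change exists, so any step is judged without a comparator. The expected step of a 1.3-fold higher number from compound 1 to compound 3 (0.12 log units; within the scatter) is small and not expected to go beyond the scatter. Compound 3 is expected to give 30 10^-6 cm/s in this assay, with a range from 12 10^-6 cm/s to 80 10^-6 cm/s.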

Compound 3, apparent permeability: 237 10^-6 cm/s
The estimate for compound 3 lay 7.9-fold (0.90 log units) below the measured number; the measured number lies above the stated range.
By their numbers in this assay, from the lowest: compound 1; then compounds 3 and 2 (each within the scatter of the next).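

In this assay, going by these compounds alone, the change on this aromatic carbon gives a 10-fold higher number from compound 1 to compound 3 (1.01 log units; beyond the scatter) and is the first single-place step. With the rest of compound 1 held constant, the group at this position alone is thus enough to move the read-out well beyond the scatter, and a ring carbon group is tolerated here without loss. No measurement at hand bears on why the step is this large.

A single step cannot separate the aromatic ring of the phenyl from the mere size of the group entering, and a cyclohexyl group at the same carbon would draw that line. Also open, as far as these compounds go, is how far the step holds once the phenyl carries a substituent such as an amine or a carboxylic acid, or when the side chain of compound 1 is changed.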